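Swapping a Chloro for Trifluoromethyl on the Outer Ring

The compounds below may be only part of what the source reports. "The series", "measured", "known", "first", "only" and "open" are said of these compounds alone.

Two benzotriazole-bearing biaryls have been measured in an ADME assay on microsomes from liver (Rattus norvegicus, strain Wistar) for metabolic stability, tested at 2.5 uM; a higher number here means faster removal of the compound, a lower number slower removal. Compound 1 `Fc1cc(C(F)(F)F)ccc1-c1ccc(Cn2nnc3ccccc32)cc1` gives 0.4 mL/min/g. Compound 2 `Clc1ccc(-c2ccc(Cn3nnc4ccccc43)cc2)c(Cl)c1` gives 1.4 mL/min/g, the higher of the two numbers, and the gap to compound 1 lies beyond the usual scatter, so compound 2 is cleared the faster of the pair.

Compound 3 `FC(F)(F)c1ccc(-c2ccc(Cn3nnc4ccccc43)cc2)c(Cl)c1` has not yet been measured. It differs from compound 2 in one place: trifluoromethyl in place of chloro on an aromatic carbon. The group sits on an aromatic carbon of a six-membered aromatic ring of carbon only.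

Among the measured compounds shown here, only two measured compounds are available, so any expectation rests thinly. Compound 1, which carries a trifluoromethyl group on its outer ring, gives 0.4 mL/min/g, which points toward a slower removal for compound 3 as well. The step of a 1.8-fold lower number from compound 2 to compound 3 (0.24 log units; within the scatter) is expected to be downward, of moderate size. Compound 3 is expected to give 0.8 mL/min/g, with a range from 0.4 mL/min/g to 1.6 mL/min/g.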

Compound 3, intrinsic clearance in a liver preparation (reported as CLH), per the amount of preparation that the assay uses: 0.5 mL/min/g
Compound 3: the middle estimate sits 1.6-fold (0.20 log units) above what was measured; the range from low to high includes it.
By their numbers in this assay, from the lowest: compounds 1 and 3 (each within the scatter of the next); then compound 2.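

On this aromatic carbon, para to a large group, trifluoromethyl in place of chloro gives a 2.8-fold lower number from compound 2 to compound 3 (0.45 log units; beyond the scatter) in this assay, so this single change is enough to separate two compounds, which the earlier pair, differing in more than one place, could not show. The other change now readable, chloro in place of fluoro on an aromatic carbon, gives a 1.3-fold higher number from compound 1 to compound 3 (0.10 log units; within the scatter) and leaves the two trifluoromethyl compounds inside the scatter of each other. No measurement at hand accounts for either step.

Open, going by these compounds, is how a methoxy group, a nitrile or an amine on this same carbon would compare with chloro and trifluoromethyl. Also open, on these data alone, is whether trifluoromethyl in place of chloro would give a similar step on another core, as this change is seen only once here.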